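This account rests on a few compounds, and the source may have more. Where it says the series, first, only, none or still open, it means among the compounds named here.

Measured compounds:

Compound 1 `Cn1nc(N)c2c(=O)[nH]c(-c3ccccc3)cc21`: in an assay on isolated protein for inhibition of serine/threonine-protein kinase Chk2 (Homo sapiens), read by mobility shift assay, tested at 30 uM (a higher number here means more inhibition at the concentration tested (going by the name of the read-out), a lower number less inhibition), compound 1 gives 16%.
Compound 2 `CC(=O)Nc1nn(C)c2cc(-c3ccccc3)[nH]c(=O)c12`: in this assay compound 2 gives 4%.
Compound 3 `Cc1cc2nn(-c3ccccc3)c(N)c2c(=O)[nH]1`: in this assay compound 3 gives -4%.

Compound 3 has the lowest number of the three. Its nearest neighbour is compound 2, which lies within the scatter of it, while compound 1 stands beyond the scatter above it. Compound 4 `COc1ccc(-c2cc3nn(-c4ccccc4)c(N)c3c(=O)[nH]2)cc1` arises from compound 3 by one change: 4-methoxyphenyl in place of methyl on an aromatic carbon.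

Within the data shown here, only one measured step exists, a number 12 percentage points lower from compound 1 to compound 2 (beyond the scatter), and it concerns an acetyl placed on a nitrogen, not a larger group placed on an aromatic carbon. It therefore gives no direct guide to the change from compound 3 to compound 4. Without a step of the same kind, the expectation can only be loose: a change in this assay of roughly a number 12 percentage points higher from compound 3 to compound 4 (beyond the scatter) is estimated, with the direction uncertain. Compound 4 is expected to give about 8%, within a range from -12% to 35%.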

Compound 4, a percentage reported as inhibition, at one concentration (the size of the read-out at that concentration, not a potency): -3%
For compound 4 the middle estimate is 11 percentage points above the measured one, within the range that was stated.
By their numbers in this assay, from the lowest: compounds 3, 4 and 2 (each within the scatter of the next); then compound 1.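

In this assay, placing 4-methoxyphenyl instead of methyl on the aromatic carbon next to the ring nitrogen gives a step that stays within the usual scatter (a number 1 percentage points higher from compound 3 to compound 4 (within the scatter)). Among these compounds, this is the first view of this position, since the only earlier step concerned a nitrogen, and it shows that a much larger group with an added aromatic ring brings no readable inhibition here, at least in this one comparison. Nothing available explains why the number fails to respond to so large a change.

On these data alone, whether an amine or a carboxylic acid on this carbon would shift the number remains open. So does whether a longer alkyl chain here would read any differently from methyl or 4-methoxyphenyl.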